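Amide series: the step from compound 3 to compound 4

The source may hold more compounds than are shown below. What is called first, only, known or untested is meant among the compounds shown, and "the series" means these compounds.

Measured so far:
compound 1 `CCOC(=O)c1c(O)c2cccnc2n(-c2ccccc2)c1=O`: 23.5%
compound 2 `CCCCNC(=O)c1c(O)c2cccnc2n(-c2ccccc2)c1=O`: 12.8%
compound 3 `COc1ccc(NC(=O)c2c(O)c3cccnc3n(-c3ccccc3)c2=O)cc1`: 0.3%

In a functional assay on the whole organism for inhibition, with Rattus norvegicus as the target, read by paw edema, at a dose of 100 mg/kg by the oral route (on this read-out lower numbers stand for less inhibition and higher numbers for more inhibition at the one dose given (going by the name of the read-out)), compound 1 gives 23.5%, compound 2 gives 12.8%, and compound 3 gives 0.3%. Compound 3 stands lowest of the three measured numbers; the gaps to it, a number 23.2 percentage points lower from compound 1 to compound 3 (beyond the scatter) and a number 12.5 percentage points lower from compound 2 to compound 3 (beyond the scatter), are both beyond the scatter, so within this small set the number for compound 3 is the lowest.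

Compound 4 `O=C(Nc1ccc([N+](=O)[O-])cc1)c1c(O)c2cccnc2n(-c2ccccc2)c1=O` differs from compound 3 in one place: nitro in place of methoxy on an aromatic carbon.

Among the compounds with values here, none of the measured steps alters a group on that aromatic ring. The nearest comparison is a number 12.5 percentage points lower from compound 2 to compound 3 (beyond the scatter), which swaps the whole group on the amide-type nitrogen, and a number 10.7 percentage points lower from compound 1 to compound 2 (beyond the scatter), which swaps the ethoxy for an amine. Both tell of the group on the carbonyl carbon, not of the para substituent of the aryl ring, so they give no direct guide here. The number for compound 3 already sits at the floor of the read-out and cannot fall much further. The expected step is therefore a number 4.7 percentage points higher from compound 3 to compound 4 (within the scatter), a change within the scatter. Compound 4 is estimated at 5%, with a range from 0% to 20%.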

Compound 4, a percentage reported as inhibition, in the whole organism at one dose (the size of the read-out at that dose, not a potency): -7.6%
The estimate for compound 4 lay 12.6 percentage points above the measured number, and the stated range ends above it.
By their numbers in this assay, from the lowest: compounds 4 and 3 (each within the scatter of the next); then compound 2; then compound 1.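

In this assay, within the data shown here, the change on an aromatic carbon para to a large group can now be read directly for the first time, and a number 7.9 percentage points lower from compound 3 to compound 4 (within the scatter) shows that nitro in place of methoxy at this position gives no difference that can be told from the scatter. The separation from the other two compounds persists with the new group: a number 20.4 percentage points lower from compound 2 to compound 4 (beyond the scatter) for 4-nitrophenyl in place of butyl on the amide-type nitrogen, and a number 31.1 percentage points lower from compound 1 to compound 4 (beyond the scatter) for (4-nitrophenyl)amino in place of ethoxy on the carbonyl carbon. Thus compound 3 and compound 4 both stand apart from compound 1 and compound 2 with either of these two groups on the aryl ring, and no measurement on hand accounts for this.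

From the compounds shown here alone, whether an amine, a carboxylic acid or a plain hydrogen on that aromatic carbon would give a number clear of the scatter around compound 3 remains open. Also open, going by these compounds, is whether a longer chain than butyl on the amide-type nitrogen would give a number different from that of compound 2 and closer to that of compound 1 in this assay and whether any amide can match the ethyl ester.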